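Compound 1 to compound 4: one group exchanged

The compounds below may be only part of what the source reports. "The series", "measured", "known", "first", "only" and "open" are said of these compounds alone.

Measured so far in a physicochemical assay for solubility, read by LC-MS, in phosphate buffer, with a stated time of 24 h, at pH 7.4 (on this read-out higher numbers stand for higher solubility and lower numbers for lower solubility), on three compounds
- compound 1 `O=C1c2ccccc2CN1c1cnc(NCc2c(F)ccc3c2CCO3)n2cnnc12` gives 4000 nM
- compound 2 `Cn1nccc1-c1cnc(NCc2c(F)ccc3c2CCO3)c2cn[nH]c(=O)c12` gives 2000 nM
- compound 3 `Cc1ncccc1-c1cnc(NCc2c(F)ccc3c2CCO3)c2cn[nH]c(=O)c12` gives < 2000 nM as a limit

Compound 1 and compound 2 stand within the scatter of each other, and no other number is available for comparison. Compound 3 sits at the limit of < 2000 nM in this assay, at which 1 of the 3 values shown sits, and gives no number. Compound 4 `CN(c1ccn(C)n1)c1cnc(NCc2c(F)ccc3c2CCO3)n2cnnc12` differs from compound 1 in one place: a group of 8 heavy atoms (5 carbon, 3 nitrogen; one five-membered aromatic ring with 2 hetero atoms) in place of a group of 10 heavy atoms (8 carbon, 1 nitrogen, 1 oxygen; one five-membered non-aromatic ring with 1 hetero atom, one six-membered aromatic ring of carbon only), on an aromatic carbon and the shared core stays unchanged. Within the data shown here, the only measured step is a number no higher from compound 2 to compound 3 (the limit leaves the size open) and it involves other groups on another core, so it offers no size to carry over. No step beyond the scatter is therefore expected in this assay and the expected step is a 1.3-fold higher number from compound 1 to compound 4 (0.10 log units; within the scatter) as a weak estimate. For compound 4 the estimated value is 5000 nM within an expected range of 1500 nM to 20000 nM in this series.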

Compound 4, solubility: 130000 nM
The estimate for compound 4 lay 26-fold (1.41 log units) below the measured number, and the stated range ends below it.
By their numbers in this assay, from the lowest: compounds 2 and 1 (each within the scatter of the next); then compound 4.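

In this assay, methyl(1-methyl-1H-pyrazol-3-yl)amino entering on this aromatic carbon of the shared core, in place of the group with two rings, gives a 33-fold higher number from compound 1 to compound 4 (1.51 log units; beyond the scatter), a large step. Among these compounds, the earlier compounds gave no step of readable size, so this is the first sign that the group at this position can move the read-out strongly. Nothing measured here bears on the reason for the step.

Which part of the entering group carries the step remains open. A morpholine or a plain dimethylamino group at this place could separate the contribution of the amine from that of the pyrazole ring.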